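The source may hold more compounds than are shown below. What is called first, only, known or untested is meant among the compounds shown, and "the series" means these compounds.

Measured so far:
compound 1 `N#Cc1ccccc1OC1CCN(c2ccc(-n3ccnc3)nn2)CC1` — 236 nM
compound 2 `Oc1nnc(-c2ccc(N3CCC(Oc4ccccc4C(F)(F)F)CC3)nn2)s1` — 6.1 nM

In an assay on microsomes from liver for inhibition of acyl-CoA desaturase 1 (Rattus norvegicus) (a lower number here means a stronger inhibitor, a higher number a weaker inhibitor), compound 2 gives 6.1 nM, the lowest of the two numbers; compound 1 gives 236 nM, a gap beyond the scatter. Among the compounds with values here, no pair of measured compounds differing in a single place is available, so no measured step exists for any change. Compound 3 `CC(C)Cc1nnc(-c2ccc(N3CCC(Oc4ccccc4C(F)(F)F)CC3)nn2)o1` carries 5-isobutyl-1,3,4-oxadiazol-2-yl in place of 5-hydroxy-1,3,4-thiadiazol-2-yl on an aromatic carbon. Lacking a measured precedent, only a small step is expected here, likely toward a weaker number, as a 2.0-fold higher number from compound 2 to compound 3 (0.29 log units; within the scatter) expresses. Compound 3 is expected to give about 12 nM, within 3 nM to 50 nM.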

Compound 3, half-maximal inhibitory concentration: 15 nM
Compound 3: the middle estimate sits 1.3-fold (0.10 log units) below what was measured, within the range that was stated.
By their numbers in this assay, from the lowest: compound 2; then compound 3; then compound 1.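

In this assay, the aromatic carbon para to a large group accepts 5-isobutyl-1,3,4-oxadiazol-2-yl in place of 5-hydroxy-1,3,4-thiadiazol-2-yl, with a 2.5-fold higher number from compound 2 to compound 3 (0.39 log units; beyond the scatter) as a modest cost. Compound 3 still gives 15 nM with no hydrogen-bond donor in this group, so a donor here is not required for a low number. Nothing available explains the size of this step.

As far as these compounds go, the ring and its substituent change together, and their separate shares remain open. Also open, from the compounds shown here alone, is how an amine, a carboxylic acid or a longer chain in place of isobutyl would read.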